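Trimming an Aminoglycoside Fragment: Toll on Cell Viability

The compounds below may be only part of what the source reports. "The series", "measured", "known", "first", "only" and "open" are said of these compounds alone.

Of the compounds shown here, three have so far been tested in a toxicity assay on the whole organism (J774 cells) for cytotoxicity, with Mus musculus as the target, read by MTT assay, with a stated time of 24 h, tested at 10 uM; a lower number here means a stronger effect, a higher number a weaker effect of the compound at the concentration tested. Compound 1 `CCCCCCCCCO[C@@H]1[C@@H](N)[C@@H](OC[C@H](O)CN=[N+]=[N-])O[C@H](CN)[C@H]1OCCCCCCCCC` gives 62.2%. Compound 2 `CCCCCCCCCO[C@@H]1[C@@H](N)[C@@H](O[C@H]2[C@H](O)[C@@H](OCCCCCCCCC)[C@H](N)C[C@@H]2N)O[C@H](CN)[C@H]1O` gives 78.4%. Compound 3 `NC[C@H]1O[C@H](O[C@H]2[C@H](O)[C@@H](O)[C@H](N)C[C@@H]2N)[C@H](N)[C@@H](OCCCc2ccc3ccccc3c2)[C@@H]1OCCCc1ccc2ccccc2c1` gives 87.7%, the highest number of the three; its difference from compound 2 is within the usual scatter, while its difference from compound 1 lies beyond it. No single-point change links any two of these measured compounds, so the numbers stand on their own.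

Compound 4 `C=CCO[C@H]1O[C@H](CN)[C@@H](OCCCc2ccc3ccccc3c2)[C@H](OCCCc2ccc3ccccc3c2)[C@H]1N` has not yet been measured in this assay. It is built from compound 3 by one change: allyl in place of 4,6-diamino-2,3-dihydroxycyclohexyl on an oxygen on a saturated carbon. The whole sugar-like ring carrying two amino and two hydroxyl groups is gone, and a short three-carbon allyl chain stands in its place, so a large part of compound 3 disappears.

Among the compounds already tested, the one without that aminated ring, compound 1, gives the lowest number, 62.2%. On that basis a downward step from compound 3 to compound 4 of about a number 22.7 percentage points lower from compound 3 to compound 4 (beyond the scatter) is expected, beyond the scatter. Compound 4 is therefore estimated to give 65%, within a range of 45% to 85%.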

Compound 4, a percentage reported as activity, at one concentration (the size of the read-out at that concentration, not a potency): 105%
Beside the measured number, compound 4's estimate is 40 percentage points below it; the whole stated range lies below it.
By their numbers in this assay, from the lowest: compound 1; then compounds 2 and 3 (each within the scatter of the next); then compound 4.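

In this assay, putting allyl in place of 4,6-diamino-2,3-dihydroxycyclohexyl on an oxygen on a saturated carbon gives a number 17.3 percentage points higher from compound 3 to compound 4 (beyond the scatter), a move towards a weaker effect of the compound at the concentration tested. Among these compounds, this is the first direct reading of a single change in this set, and it shows that at this position the whole ring carrying the amino and hydroxyl groups can be removed without the number going down, with the two naphthalene-bearing side chains left in place. Nothing available explains why the number rises with this swap.

The swap removes the ring, its amino groups and its hydroxyl groups together and brings in a double bond, so this single step cannot show which of these differences matters for the result. A propyl chain on the same oxygen would test the double bond alone, while a 2-aminoethyl group would show whether one amine on a short chain gives a number closer to that of compound 3 or to that of compound 4.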